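This account rests on a few compounds, and the source may have more. Where it says the series, first, only, none or still open, it means among the compounds named here.

Working notes on the series. Of the compounds shown here, two have been measured in an assay for displacement of a labelled ligand from growth hormone secretagogue receptor type 1 (Homo sapiens), read by scintillation counting; on this read-out lower numbers stand for stronger inhibition and higher numbers for weaker inhibition. Compound 1 `Cc1nc2ncc(Oc3ccc(Br)cc3F)cc2c(=O)n1C[C@H]1CCCN(C(C)C)C1` gives 0.16 nM in this assay. Compound 2 `Cc1nc2ncc(Oc3ccc(F)c4cccnc34)nc2c(=O)n1C[C@H]1CCCN(C(C)C)C1` gives 1.9 nM in this assay, the higher of the two numbers; the nearest measured compound is compound 1, which sits at a markedly lower number, a gap beyond the usual scatter.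

The next compound in the series is compound 3 `Cc1nc2ncc(Oc3ccc(Br)cc3F)nc2c(=O)n1C[C@H]1CCCN(C(C)C)C1`, not yet measured in this assay. It differs from compound 2 in one place: 4-bromo-2-fluorophenyl in place of 5-fluoroquinolin-8-yl on an oxygen on an aromatic ring. Compound 3 thus carries the same aryl ether as compound 1 on the core of compound 2, so the two measured compounds bracket what is known about both parts of its structure.

For the measured compounds named here, no step between measured compounds with this exact change has been recorded. The step from compound 2 to compound 3 is nevertheless expected to lower the number by a clear margin, since compound 1 with this aryl ether gives 0.16 nM; the expected step is a 3.8-fold lower number from compound 2 to compound 3 (0.58 log units; beyond the scatter). Compound 3 is therefore estimated to give 0.5 nM in this assay, within an expected range from 0.1 nM to 2.5 nM.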

Compound 3, inhibition constant: 0.05 nM
Compound 3: middle estimate off by 10-fold (1.00 log units), on the high side, outside the stated range (below it).
By their numbers in this assay, from the lowest: compound 3; then compound 1; then compound 2.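

Within this assay, 4-bromo-2-fluorophenyl in place of 5-fluoroquinolin-8-yl on the ether oxygen gives a 38-fold lower number from compound 2 to compound 3 (1.58 log units; beyond the scatter), which shows that the number on this core depends strongly on the aryl group at this position and that the smaller single-ring group, with no hydrogen-bond acceptor, is the better of the two here. The same aryl ether also sits on a different core: compound 1 gives 0.16 nM and compound 3 gives 0.05 nM, so this group carries low numbers on both cores shown. Nothing measured on these compounds accounts for the size of the step.

The step swaps the whole aryl group at once, so the shares of the bromine, the fluorine and the second ring cannot be told apart; a plain phenyl, or a chlorine or a nitrile in place of the bromine, would begin to separate them. On these data alone, how 5-fluoroquinolin-8-yl behaves on the core of compound 1 also remains open, so whether the size of this step carries over from one core to the other cannot be read.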